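The compounds below may be only part of what the source reports. "The series", "measured", "known", "first", "only" and "open" are said of these compounds alone.

Series values in a functional assay on BT-483 cells (Homo sapiens) for cytotoxicity, read by MTT assay, with a stated time of 24 h; on this read-out lower numbers stand for stronger inhibition and higher numbers for weaker inhibition:
- compound 1 `CCNc1cc(-c2ccc(NC(=O)Nc3ccc(C(F)(F)F)cc3)cc2C)ccn1`: 19700 nM
- compound 2 `CCNc1cc(-c2ccc(NC(=O)Nc3ccc(C(F)(F)F)cc3)cc2C(F)(F)F)ccn1`: 16400 nM
- compound 3 `CCNc1cc(-c2ccc(NC(=O)Nc3ccc(OC)cc3)cc2OC)ccn1`: > 30000 nM (a limit)

Compound 3 gives no number and stands at the limit of > 30000 nM in this assay, at which 1 of the 3 values shown sits.

Compound 4 `CCNc1cc(-c2ccc(NC(=O)Nc3ccc(C(F)(F)F)cc3)cc2OC)ccn1` differs from compound 3 by trifluoromethyl in place of methoxy on an aromatic carbon, para to a large group (trifluoromethyl in place of methoxy on an aromatic carbon). The same difference reads as 4-methoxyphenyl to 4-(trifluoromethyl)phenyl. Among the measured compounds shown here, no measured step covers this exact change.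

For the measured compounds named here, the one measured step, a 1.2-fold lower number from compound 1 to compound 2 (0.08 log units; within the scatter), is trifluoromethyl in place of methyl on an aromatic carbon, at a different place from the change in question. It bears only indirectly, but it shows that compound 1 and compound 2 cannot be told apart in this assay. Both carry the 4-(trifluoromethyl)phenyl that compound 4 gains. Compound 4 keeps a methoxy where compound 1 has methyl and compound 2 has trifluoromethyl. It is therefore expected to read close to that pair, with compound 2 at 16400 nM as the nearest anchor alongside compound 1 at 19700 nM.

The expected change is an at least 1.6-fold lower number from compound 3 to compound 4 (0.22 log units; that floor lies within the scatter), in the direction of a lower number. For compound 4 the estimated value is 18000 nM, with an expected range of 9000 nM to 30000 nM.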

Compound 4, half-maximal inhibitory concentration: 25600 nM
For compound 4 the middle estimate is 1.4-fold (0.15 log units) below the measured one; measured number inside the range.
By their numbers in this assay, from the lowest: compounds 2, 1 and 4 (each within the scatter of the next). At a limit, above all of these: compound 3.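

In this assay, the change from 4-methoxyphenyl to 4-(trifluoromethyl)phenyl now has a first reading, an at least 1.1-fold lower number from compound 3 to compound 4 (0.06 log units; that floor lies within the scatter), which gives only a floor for the step and not its size. Compound 3 gives no number, only a limit of the assay: the limit of > 30000 nM in this assay, at which 1 of the 4 values shown sits. With 4-(trifluoromethyl)phenyl in place, the methoxy of compound 4 joins the methyl and trifluoromethyl at the other place of variation, with a 1.3-fold higher number from compound 1 to compound 4 (0.11 log units; within the scatter) and a 1.6-fold higher number from compound 2 to compound 4 (0.19 log units; within the scatter), so these three groups cannot be told apart there in this assay.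

On these data alone, the true size of the change from methoxy to trifluoromethyl remains open, as does whether it lowers the number beyond the scatter at all. Also open, as far as these compounds go, is how a chlorine, a nitrile or a dimethylamino group would read in place of the trifluoromethyl of the 4-(trifluoromethyl)phenyl, or at the place where methyl, trifluoromethyl and methoxy have so far read alike.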